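The source may report more compounds than this note shows. Statements on the series, on what has been measured and on what is new or still open speak of the compounds shown alone.

Compound 1, `COc1ccc(CCC(=O)c2cccc(O)c2)cc1`, in an ADME assay on RAW264.7 cells (Mus musculus) for cytotoxicity, read by MTT assay, with a stated time of 24 h, tested at 1.25 ug/mL (on this read-out lower numbers stand for a stronger effect and higher numbers for a weaker effect at the one concentration tested), gives 97.5%.
Compound 2, `COc1ccc(CCC(=O)c2cccc(O)c2)c(OC)c1`, in this assay gives 92.1%.
Compound 3, `COc1ccc(C(=O)CCc2ccc(OC)c(OC)c2)c(O)c1`, in this assay gives 91.8%.

Three measured compounds sit close together in this assay, all three numbers within the scatter of one another. Compound 1 and compound 2 differ in one place, (methoxy in place of hydrogen on an aromatic carbon), and this change made a step of a number 5.4 percentage points lower from compound 1 to compound 2 (within the scatter). How the core of compound 3 relates to that of compound 1 is not broken down here.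

Compound 4, `COc1ccc(C(=O)CCc2ccc(OC)c(OC)c2OC)c(O)c1`, is still to be measured in this assay. It differs from compound 3 by methoxy in place of hydrogen on an aromatic carbon. Within the data shown here, this is the same kind of change as the one from compound 1 to compound 2, though not the same: in compound 4 the entering methoxy is also ortho to a methoxy group, which it was not in compound 2.

Because the earlier step of a number 5.4 percentage points lower from compound 1 to compound 2 (within the scatter) stayed within the scatter, the step from compound 3 to compound 4 is expected to be small as well, about a number 1.8 percentage points lower from compound 3 to compound 4 (within the scatter). Compound 4 is therefore estimated at 90%, with the range 82% to 98%.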

Compound 4, a percentage reported as activity, at one concentration (the size of the read-out at that concentration, not a potency): 101%
Compound 4: the middle estimate sits 11 percentage points below what was measured; measured number outside the range, above it.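

In this assay, putting methoxy in place of hydrogen on an aromatic carbon gave a step of a number 9.2 percentage points higher from compound 3 to compound 4 (within the scatter), and set beside the earlier step, this shows that the change does not carry over from one core to another as a fixed shift: the same change on two cores in this assay, a number 5.4 percentage points lower (within the scatter) from compound 1 to compound 2 and a number 9.2 percentage points higher (within the scatter) from compound 3 to compound 4, 14.6 percentage points apart, beyond the scatter of two such steps

What this does not show is that methoxy itself moves the number in either core, as each step taken alone stays within the scatter. Nor can two steps separate the effect of the core from that of the place, as the entering methoxy in compound 4 is ortho to a methoxy group, which it was not in compound 2.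

The compounds shown leave open how the same change would behave on a core carrying an amine, a carboxylic acid or a longer chain. They also leave open whether an ethoxy group entering at the same places would give steps that agree any better.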